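A Single Aryl Swap on the Shared Core of Compound 1

This account rests on a few compounds, and the source may have more. Where it says the series, first, only, none or still open, it means among the compounds named here.

Measured so far in a functional assay on HepG2 cells (Homo sapiens) for inhibition, read by MTT assay, with a stated time of 72 h; a lower number here means a stronger inhibitor, a higher number a weaker inhibitor:
Compound 1, `Cc1ccc(-n2cc(COc3cccc(NC(=O)Nc4ccc(Cl)c(C(F)(F)F)c4)c3)nn2)cc1`, gives 5430 nM.
Compound 2, `N#Cc1cccc(-n2cc(COc3cccc(NC(=O)Nc4ccc(Cl)c(C(F)(F)F)c4)c3)nn2)c1`, gives 2760 nM.

Of these two numbers, compound 1 has the higher one, but compound 2 lies within the usual scatter of it, so the two cannot be ordered. Going by the values given here, the only measured step that touches the same place is a 2.0-fold lower number from compound 1 to compound 2 (0.29 log units; within the scatter), and it stayed within the scatter.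

Compound 3, `O=C(Nc1cccc(OCc2cn(-c3cccc(C(F)(F)F)c3)nn2)c1)Nc1ccc(Cl)c(C(F)(F)F)c1`, differs from compound 1 in one place: 3-(trifluoromethyl)phenyl in place of 4-methylphenyl on an aromatic nitrogen. Among the compounds with values here, no measured compound carries the entering group, so the expectation rests on the one step at that position. Because a 2.0-fold lower number from compound 1 to compound 2 (0.29 log units; within the scatter) was within the scatter, a small or no step beyond the scatter is expected in this assay. For compound 3 the estimate is 3500 nM, with a range from 1500 nM to 8500 nM. For compound 3 this means an expected 1.6-fold lower number from compound 1 to compound 3 (0.19 log units; within the scatter).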

Compound 3, half-maximal inhibitory concentration: 1270 nM
Compound 3: the middle estimate sits 2.8-fold (0.44 log units) above what was measured; the whole stated range lies above it.
By their numbers in this assay, from the lowest: compound 3; then compounds 2 and 1 (each within the scatter of the next).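

In this assay, this position now gives a change that lies beyond the scatter: 3-(trifluoromethyl)phenyl in place of 4-methylphenyl on an aromatic nitrogen gives a 4.3-fold lower number from compound 1 to compound 3 (0.63 log units; beyond the scatter). Trifluoromethyl in place of cyano on an aromatic carbon also gives a 2.2-fold lower number from compound 2 to compound 3 (0.34 log units; beyond the scatter), so the substituent on this aryl group can shift the number by a modest step, which the pair of compound 1 and compound 2 could not show. Nothing available here accounts for either step.

The compounds shown leave open whether an aryl group carrying an amine or a carboxylic acid would extend this step or reverse it. They also leave open whether 4-(trifluoromethyl)phenyl on the same aromatic nitrogen would match 3-(trifluoromethyl)phenyl.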